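This account rests on a few compounds, and the source may have more. Where it says the series, first, only, none or still open, it means among the compounds named here.

Compound 1 `Nc1ccccc1NC(=O)/C=C/c1ccc(CSc2ccc(F)cc2)cc1` sits lowest of the three measured values in a functional assay on HeLa cells (Homo sapiens) for inhibition, read by CCK-8 assay, with a stated time of 72 h, tested at 2 uM (on this read-out higher numbers stand for more inhibition of growth at the one concentration tested and lower numbers for less inhibition of growth), where compound 1 gives 7.09%. Compound 2 `Cc1ccc(SCc2ccc(C(=O)Nc3ccccc3N)cc2)cc1` gives 33.8% and compound 3 `CCc1ccc(SCc2ccc(C(=O)Nc3ccccc3N)cc2)cc1` gives 30.8%, both well apart from compound 1 on the same read-out. Among the compounds with values here, the only step measured within one change is a number 3 percentage points lower from compound 2 to compound 3 (within the scatter), which concerns a different part of the molecule and a different core. Within the data shown here, compound 4 `Nc1ccccc1NC(=O)/C=C/c1ccc(CSCCc2ccccc2)cc1` carries the change (phenethyl in place of 4-fluorophenyl on a sulfur); no measured step bears on this swap at the sulfur, so nothing in the data supports a shift beyond the scatter in this assay. Compound 4 is therefore expected to stay near compound 1, with the step of a number 2.9 percentage points higher from compound 1 to compound 4 (within the scatter) estimated as small. The estimate for compound 4 is 10%, from 0% to 25%.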

Compound 4, percent growth inhibition at one concentration: 0.19%
The estimate for compound 4 lay 9.8 percentage points above the measured number, within the range that was stated.
By their numbers in this assay, from the lowest: compounds 4 and 1 (each within the scatter of the next); then compounds 3 and 2 (each within the scatter of the next).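

In this assay, within the data shown here, phenethyl in place of 4-fluorophenyl on a sulfur gives a number 6.9 percentage points lower from compound 1 to compound 4 (within the scatter) and is the first measured change at this position. On the core of compound 1, the two groups therefore cannot be told apart in this assay, although phenethyl brings a saturated chain in front of the aromatic ring. No measurement available here bears on this result.

From the compounds shown here alone, whether a longer chain or a chain ending in an amine on this sulfur would shift the number beyond the scatter remains open. Also open, going by these compounds, is whether phenethyl would give a step of similar size on the core of compound 2.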